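Anilino swap from compound 2 to compound 3

A few compounds are considered here, and "the series" means these few. Any claim that something is new, unique, unknown or untested is made for them only; others in the source may bear on it.

Two measured compounds frame the series. Compound 1 `C#CCSc1nc(Nc2cccc(C(F)(F)F)c2)c(C#N)c(-c2ccccc2)n1` gives no number in a functional assay on ECa-109 cells (Homo sapiens) for inhibition, read by MTT assay, with a stated time of 72 h; a higher number here means a weaker inhibitor, a lower number a stronger inhibitor; its value of > 128000 nM is a limit of the assay. Compound 2 `N#Cc1c(Nc2ccccc2Cl)nc(SCc2cn(Cc3ccccc3Cl)nn2)nc1-c1ccccc1` gives 28500 nM in this assay, the only number shown, so there is no other number to rank it against. One further value shown is a limit, (the limit of > 128000 nM in this assay, at which 1 of the 2 values shown sits). Compound 3 `Cc1cccc(Nc2nc(SCc3cn(Cc4ccccc4Cl)nn3)nc(-c3ccccc3)c2C#N)c1` is not yet measured. It differs from compound 2 by 3-methylphenyl in place of 2-chlorophenyl on a nitrogen on an aromatic ring. Within the data shown here, no measured pair shows what such a change does; the step from compound 2 to compound 3 is expected to stay within the scatter, leaning if anything toward a weaker inhibitor, a 1.3-fold higher number from compound 2 to compound 3 (0.12 log units; within the scatter). Compound 3 is therefore estimated at 38000 nM in this assay, within 12000 nM to 120000 nM.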

Compound 3, half-maximal inhibitory concentration: 15600 nM
Compound 3: the middle estimate sits 2.4-fold (0.39 log units) above what was measured, and the stated range covers the measured number.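

In this assay, among these compounds, the change from (2-chlorophenyl)amino to (3-methylphenyl)amino gives a 1.8-fold lower number from compound 2 to compound 3 (0.26 log units; within the scatter) and is the first measured pair at this nitrogen on an aromatic ring. The two values cannot be told apart, so this position takes either aryl group without a step beyond the scatter. Nothing measured here speaks to a cause for the step.

Chlorine and methyl differ here both in identity and in place on the ring, and the pair does not separate the two; 2-methylphenyl and 3-chlorophenyl on the same nitrogen would. Also open, on these data alone, is whether a more different group here, such as a carboxylic acid on the phenyl ring or a saturated amine in place of the anilino group, moves the number beyond the scatter.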